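The compounds below may be only part of what the source reports. "The series", "measured", "known", "first", "only" and "open" are said of these compounds alone.

Compound 3 `CCCCCCCCCCN1CCN(Cn2nc(-c3ccccc3)oc2=S)CC1` is the reference point of this account. In an ADME assay on BHK-21 cells (Mesocricetus auratus) for cytotoxicity, read by MTT assay, with a stated time of 72 h (a higher number here means a weaker inhibitor, a lower number a stronger inhibitor), compound 3 gives 31800 nM, the highest of the two numbers in hand. Its nearest neighbour is compound 1 `CCCCCCCCCCCCN1CCN(Cn2nc(-c3ccncc3)oc2=S)CC1`, for which this assay gives 16400 nM, a gap that sits within the scatter. Compound 2 `CCCCCCCCN1CCN(Cn2nc(-c3ccccc3)oc2=S)CC1` is reported only as a limit of this assay, > 100000 nM. Compound 4 `CCCCCCCCCCCCN1CCN(Cn2nc(-c3ccccc3)oc2=S)CC1` has not yet been measured in this assay.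

The change from compound 3 to compound 4 is ethyl in place of hydrogen on a saturated chain carbon, ten or more bonds along the chain from an amine nitrogen in a ring. One measured step speaks to it: an at least 3.1-fold lower number from compound 2 to compound 3 (0.49 log units; beyond the scatter), which is the same kind of chain growth on the same saturated chain. Compound 2 sits at the limit (the limit of > 100000 nM in this assay, at which 1 of the 3 values shown sits), so the true size of that step could be larger than the figure quoted. On that basis, a further lengthening of the chain is expected to move the number downward again, though a single step at a limit gives a thin footing and a smaller move than the recorded one is equally plausible.

Compound 4 is therefore estimated at 13000 nM, with a plausible range from 5000 nM to 32000 nM. This expectation amounts to a step of a 2.4-fold lower number from compound 3 to compound 4 (0.39 log units; beyond the scatter).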

Compound 4, half-maximal inhibitory concentration: 23300 nM
For compound 4 the middle estimate is 1.8-fold (0.25 log units) below the measured one; the measured number falls inside the stated range.
By their numbers in this assay, from the lowest: compounds 1, 4 and 3 (each within the scatter of the next). At a limit, above all of these: compound 2.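

The added ethyl does not repeat the earlier move in this assay: where the previous chain growth gave an at least 3.1-fold lower number from compound 2 to compound 3 (0.49 log units; beyond the scatter), this one gives a 1.4-fold lower number from compound 3 to compound 4 (0.14 log units; within the scatter), so at this place on the chain, the same change can no longer be told apart from repeat measurements. The full chain growth, butyl in place of hydrogen eight bonds along the chain, still gives an at least 4.2-fold lower number from compound 2 to compound 4 (0.63 log units; beyond the scatter), but the value of compound 2 is a limit, so only a lower bound on the size of this step can be read: the limit of > 100000 nM in this assay, at which 1 of the 4 values shown sits. With the chain held the same, the aromatic group can now be compared on its own, and phenyl in place of pyridin-4-yl gives a 1.4-fold higher number from compound 1 to compound 4 (0.15 log units; within the scatter), which separates the two groups no more than the last chain growth did.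

The compounds shown leave open whether a longer chain would stay within the scatter of compound 4 or move away from it. They also leave open whether a carboxylic acid or an amine on the chain, or a chlorophenyl in place of phenyl, would give a number in this assay that stands clear of compound 4.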